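This account rests on a few compounds, and the source may have more. Where it says the series, first, only, none or still open, it means among the compounds named here.

Compound 1 `COCc1cc(O)c(Cc2cc(O)c(Cc3cc(O)ccc3O)cc2O)cc1O`: 33300 nM
Compound 2 `COCc1cc(O)cc(Cl)c1O`: 6700 nM

In a functional assay on HL-60 cells (Homo sapiens) for cytotoxicity, read by MTT assay (a higher number here means a weaker inhibitor, a lower number a stronger inhibitor), compound 2 gives the lowest of these two numbers, and compound 1 stands above it by a gap that lies beyond the usual scatter. Compound 3 `COCc1cc(O)ccc1O` differs from compound 2 in one place: hydrogen in place of chloro on an aromatic carbon. Within the data shown here, no pair of measured compounds shows what such a change does here, so the direction is uncertain. A small loss of potency, a step of modest size rather than none, is expected, and the estimated step is a 1.8-fold higher number from compound 2 to compound 3 (0.25 log units; within the scatter). For compound 3 the expected value is 12000 nM, within a range from 4000 nM to 40000 nM.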

Compound 3, half-maximal inhibitory concentration: 58900 nM
The estimate for compound 3 lay 4.9-fold (0.69 log units) below the measured number; measured number above the stated range.
By their numbers in this assay, from the lowest: compound 2; then compounds 1 and 3 (each within the scatter of the next).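

In this assay, replacing the chloro group with hydrogen on the aromatic carbon ortho to a hydroxy group gives an 8.8-fold higher number from compound 2 to compound 3 (0.94 log units; beyond the scatter). Among these compounds, this is the first pair differing in one place, and it shows that inhibition in these cells is weaker without the chloro group at this position. No available evidence explains this loss. Going by these compounds, whether bromo, methyl or an amine on this carbon would match chloro remains open. It is also unknown whether adding chloro to the core of compound 1 would produce a similar gain.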